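A few compounds are considered here, and "the series" means these few. Any claim that something is new, unique, unknown or untested is made for them only; others in the source may bear on it.

Measured compounds:
compound 1, `COc1ncc(C(F)(F)F)cc1CO[C@H]1[C@H](C(C)(C)C)[C@@H](C(=O)O)N(C(=O)C2CCCCC2)[C@H]1c1ccccc1` — 150 nM
compound 2, `COc1ncc(C2CCCC2)cc1CO[C@H]1[C@H](C(C)(C)C)[C@@H](C(=O)O)N(C(=O)C2CCCCC2)[C@H]1c1ccccc1` — 247 nM
compound 3, `COc1ncc(C(C)(C)C)cc1CO[C@H]1[C@H](C(C)(C)C)[C@@H](C(=O)O)N(C(=O)C2CCCCC2)[C@H]1c1ccccc1` — 132 nM

All three values come from an assay on cells with Cystic fibrosis transmembrane conductance regulator variant F508del (Homo sapiens) as the target, read by voltage clamp, with a stated time of 24 h, in the presence of a further agent that is not named here; on this read-out lower numbers stand for an effect already at smaller amounts and higher numbers for an effect only at larger amounts of compound. Compound 1 stands second highest of the three numbers in this assay; its nearest neighbour is compound 3 with a 1.1-fold lower number from compound 1 to compound 3 (0.06 log units; within the scatter), its furthest compound 2 with a 1.6-fold higher number from compound 1 to compound 2 (0.22 log units; within the scatter). Between compound 2 and compound 3 the step is a 1.9-fold lower number from compound 2 to compound 3 (0.27 log units; within the scatter). Every measured step concerns the group on the aromatic carbon, and none of them leaves the scatter.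

Compound 4, `COc1ncc(C(F)(F)F)cc1CO[C@H]1[C@H](C(C)(C)C)[C@@H](C(=O)O)N(C(=O)[C@H]2CCCCO2)[C@H]1c1ccccc1`, is not yet measured. It differs from compound 1 by oxan-2-yl in place of cyclohexyl on a carbonyl carbon; the oxan-2-yl ring has one defined stereocentre. For the measured compounds named here, no measured step touches the carbonyl carbon next to the ring amide-type nitrogen, so the measured steps give no direct guide here; they only show that the series so far moves within the scatter. The expected step from compound 1 to compound 4 in this assay is therefore taken as a 1.3-fold higher number from compound 1 to compound 4 (0.12 log units; within the scatter), with a wide range to allow for the untested place of change. Compound 4 is estimated at 200 nM, between 70 nM and 600 nM.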

Compound 4, half-maximal effective concentration: 346 nM
The estimate for compound 4 lay 1.7-fold (0.24 log units) below the measured number, and the stated range covers the measured number.
By their numbers in this assay, from the lowest: compounds 3, 1, 2 and 4 (each within the scatter of the next, the first and the last beyond it).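

In this assay, for the compounds shown here, the group on the carbonyl carbon is the first place where a single change leaves the scatter: oxan-2-yl in place of cyclohexyl gives a 2.3-fold higher number from compound 1 to compound 4 (0.36 log units; beyond the scatter). The exchange is small on paper, since both groups are six-membered non-aromatic rings with 6 heavy atoms, and the entering ring differs by 1 oxygen, 1 hydrogen-bond acceptor and 1 defined stereocentre. Nothing at hand explains the step.

Open, as far as these compounds go, is how much of the step belongs to the ring oxygen and how much to the stereocentre, and whether the other stereoisomer of oxan-2-yl would read the same. Also open, from the compounds shown here alone, is how a piperidin-2-yl amine or a longer open chain would compare on this carbonyl carbon, and whether the step carries over to the tert-butyl and cyclopentyl compounds.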